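Cyclopentylamino on the pyridine of a TRPV1 antagonist

This account rests on a few compounds, and the source may have more. Where it says the series, first, only, none or still open, it means among the compounds named here.

Of the compounds shown here, three have been measured in a functional assay for antagonist activity at transient receptor potential cation channel subfamily V member 1 (Homo sapiens), read by FLIPR; on this read-out higher numbers stand for weaker inhibition and lower numbers for stronger inhibition. Compound 1 `C[C@@H]1CN(c2ncccc2C(F)(F)F)CCN1C(=O)Nc1ccc(C(F)(F)F)cc1` gives 17 nM. Compound 2 `N#Cc1ccc(NC(=O)c2ccc(-c3ncccc3C(F)(F)F)cc2)cc1` gives 417 nM. Compound 3 `CC(C)(C)c1ccc(NC(=O)c2ccc(-c3ccccn3)cc2)cc1` gives 11 nM; its number and that of compound 1 lie within the scatter of each other, so no order between them can be read, while the number of compound 2 stands beyond the scatter above both.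

Compound 4 `CC(C)(C)c1ccc(NC(=O)c2ccc(-c3ncccc3NC3CCCC3)cc2)cc1` has not yet been measured. It differs from compound 3 in one place: cyclopentylamino in place of hydrogen on an aromatic carbon. Going by the values given here, no measured pair shows this exact change on its own, so the size of the step has to be guessed from the fact that compound 2, which also carries a group at this place but differs in a second place as well, gives a weaker value than compound 3.

In this assay compound 4 is expected to give about 20 nM, with a range from 4 nM to 100 nM. The estimated step of a 1.8-fold higher number from compound 3 to compound 4 (0.26 log units; within the scatter) is expected to be small, most likely within the scatter.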

Compound 4, half-maximal inhibitory concentration: 190 nM
For compound 4 the middle estimate is 9.5-fold (0.98 log units) below the measured one; the whole stated range lies below it.
By their numbers in this assay, from the lowest: compounds 3 and 1 (each within the scatter of the next); then compound 4; then compound 2.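

In this assay, cyclopentylamino on this aromatic carbon, ortho to a large group and two atoms from the ring nitrogen, gives a 17-fold higher number from compound 3 to compound 4 (1.24 log units; beyond the scatter), a large loss of inhibition. Going by these compounds alone, this is the first reading of this place on its own, since no earlier pair differed only here, and it shows that the place does not accept this group without a clear cost. Nothing measured on these compounds bears on the reason for the loss, so the result stands without an explanation.

From the compounds shown here alone, whether the loss follows the cyclopentyl ring or the linking nitrogen stays open, as does how a plain amino group, a methylamino group or a cyclopentyloxy group would behave at this place. Also open, going by these compounds, is whether the step would keep its size on a core other than that of compound 3.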